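Halogen swap on the shared aryl urea

The source may report more compounds than this note shows. Statements on the series, on what has been measured and on what is new or still open speak of the compounds shown alone.

Measured compounds and their values in an ADME assay on the whole organism with Oryza sativa as the target, tested at 10 uM; on this read-out lower numbers stand for a stronger effect and higher numbers for a weaker effect at the one concentration tested:
compound 1, `CCc1ccccc1NC(=O)N[C@@H](C)c1ccccc1`: 95%
compound 2, `CC(=O)c1ccccc1NC(=O)N[C@@H](C)c1ccccc1`: 96%
compound 3, `C[C@H](NC(=O)Nc1ccccc1Cl)c1ccccc1`: 106%

Compound 3 carries a chloro group on the shared core. In this assay compound 3 gives 106%; one of the steps leading to it is a number 10 percentage points higher from compound 2 to compound 3 (within the scatter), so those two cannot be told apart, while the other is a number 11 percentage points higher from compound 1 to compound 3 (beyond the scatter), a modest but real difference.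

Compound 4, `C[C@H](NC(=O)Nc1ccccc1I)c1ccccc1`, has not been measured. Relative to compound 3 the change is iodo in place of chloro on an aromatic carbon, an exchange of one halogen for another on the same aromatic carbon. Among the measured compounds shown here, none of the measured steps exchanges one halogen for another; the two steps that bring in the chloro group, a number 11 percentage points higher from compound 1 to compound 3 (beyond the scatter) and a number 10 percentage points higher from compound 2 to compound 3 (within the scatter), are small and sit at or near the scatter. For the measured compounds named here, with no closer precedent, the expectation is that the step to compound 4 stays within the scatter, a number 2 percentage points lower from compound 3 to compound 4 (within the scatter). Compound 4 is therefore estimated at 104%, with a range from 92% to 114%.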

Compound 4, a percentage reported as activity, at one concentration (the size of the read-out at that concentration, not a potency): 98%
For compound 4 the middle estimate is 6 percentage points above the measured one; measured number inside the range.
By their numbers in this assay, from the lowest: compounds 1, 2, 4 and 3 (each within the scatter of the next, the first and the last beyond it).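

In this assay, the exchange of one halogen for another on this aromatic carbon gives no difference that can be told apart (in the step of a number 8 percentage points lower from compound 3 to compound 4 (within the scatter)). Iodo also stays level with the two non-halogen groups at this position (acetyl in the step of a number 2 percentage points higher from compound 2 to compound 4 (within the scatter), ethyl in the step of a number 3 percentage points higher from compound 1 to compound 4 (within the scatter)), so a halogen here does not in itself set a compound apart from ethyl: only chloro does so, and iodo does not. Nothing available here bears on what lies behind these numbers.

On these data alone, whether fluoro or bromo would stay equally level at this aromatic carbon remains open. So does whether a group of another kind there, such as an amine or a carboxylic acid, would move the read-out beyond the scatter.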